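Swapping tert-butyl for cyclohexyl on the urea nitrogen

The source may report more compounds than this note shows. Statements on the series, on what has been measured and on what is new or still open speak of the compounds shown alone.

Three measured compounds share one core and differ only in the group on an amide-type nitrogen. Compound 1 `CCNC(=O)N1CCN(C(=S)SCc2cn(Cc3ccccc3F)nn2)CC1` carries ethyl there, and in a functional assay on EC9706 cells (Homo sapiens) for cytotoxicity, read by MTT assay, with a stated time of 72 h (a higher number here means a weaker inhibitor, a lower number a stronger inhibitor), compound 1 gives 23700 nM. Compound 2 `CC(C)NC(=O)N1CCN(C(=S)SCc2cn(Cc3ccccc3F)nn2)CC1` carries isopropyl, and in this assay compound 2 gives 20800 nM. Compound 3 `CC(C)(C)NC(=O)N1CCN(C(=S)SCc2cn(Cc3ccccc3F)nn2)CC1` carries tert-butyl; in this assay compound 3 gives 87800 nM, the highest of the three numbers and thus the weakest inhibitor among them. The steps of a 3.7-fold higher number from compound 1 to compound 3 (0.57 log units; beyond the scatter) and a 4.2-fold higher number from compound 2 to compound 3 (0.63 log units; beyond the scatter) both run upward, while a 1.1-fold lower number from compound 1 to compound 2 (0.06 log units; within the scatter) does not stand out. Compound 4 `O=C(NC1CCCCC1)N1CCN(C(=S)SCc2cn(Cc3ccccc3F)nn2)CC1` takes the next step: cyclohexyl in place of tert-butyl on an amide-type nitrogen. Among the compounds with values here, no measured step exchanges tert-butyl for a ring, so the only guides are the two steps that arrive at compound 3. Because a 3.7-fold higher number from compound 1 to compound 3 (0.57 log units; beyond the scatter) and a 4.2-fold higher number from compound 2 to compound 3 (0.63 log units; beyond the scatter) both end at compound 3 as the weakest, compound 4 is expected to move modestly back toward lower numbers, the expected step being a 2.5-fold lower number from compound 3 to compound 4 (0.40 log units; beyond the scatter), with wide uncertainty since cyclohexyl is larger than either ethyl or isopropyl. Compound 4 is therefore estimated to give about 35000 nM in this assay, within a range from 12000 nM to 100000 nM.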

Compound 4, half-maximal inhibitory concentration: 84900 nM
The estimate for compound 4 lay 2.4-fold (0.38 log units) below the measured number; the measured number falls inside the stated range.
By their numbers in this assay, from the lowest: compounds 2 and 1 (each within the scatter of the next); then compounds 4 and 3 (each within the scatter of the next).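

Cyclohexyl and tert-butyl cannot be told apart on this amide-type nitrogen in this assay: the result is a 1.0-fold lower number from compound 3 to compound 4 (0.01 log units; within the scatter), so here a six-membered ring of carbon only reads the same as a group with no ring. Cyclohexyl does not share the lower numbers of the two smaller groups, with a 4.1-fold higher number from compound 2 to compound 4 (0.61 log units; beyond the scatter) and a 3.6-fold higher number from compound 1 to compound 4 (0.55 log units; beyond the scatter), which places tert-butyl and cyclohexyl together in one pair and ethyl and isopropyl in another. Nothing available explains why the two pairs separate.

Still open, as far as these compounds go, is where a smaller ring such as cyclopropyl, an aromatic ring such as phenyl, or a longer straight chain such as n-butyl would fall relative to these two pairs. Also open, from the compounds shown here alone, is whether a hydroxyl or an amine attached to the cyclohexyl ring would shift the number, and whether the same two pairs would appear in a different cell line.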